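Guanidine-bearing side chain on a sulfamoyl adenosine scaffold

This account rests on a few compounds, and the source may have more. Where it says the series, first, only, none or still open, it means among the compounds named here.

Compound 1, `CCC[C@H](N)C(=O)NS(=O)(=O)OC[C@H]1O[C@@H](n2cnc3c(N)ncnc32)[C@H](O)[C@@H]1O`: 4700 nM
Compound 2, `CC(C)C[C@H](N)C(=O)NS(=O)(=O)OC[C@H]1OC[C@@H](n2cnc3c(N)ncnc32)C[C@@H]1O`: 6800 nM

Of the compounds shown here, two have been measured in a functional assay on PBMC cells (Homo sapiens) for inhibition; on this read-out higher numbers stand for weaker inhibition and lower numbers for stronger inhibition. Compound 1 gives 4700 nM in this assay, the lower of the two numbers; compound 2 gives 6800 nM, and the gap between the two lies within the scatter, so neither can be called the stronger inhibitor. Compound 3, `N=C(N)NCCC[C@H](N)C(=O)NS(=O)(=O)OC[C@H]1O[C@@H](n2cnc3c(N)ncnc32)[C@H](O)[C@@H]1O`, has not yet been measured in this assay. It differs from compound 1 by a group of 4 heavy atoms (1 carbon, 3 nitrogen; no ring) in place of a hydrogen atom, on a saturated chain carbon, four bonds along the chain from an amine nitrogen and a carbonyl carbon. Going by the values given here, no step between measured compounds isolates a change of this kind, so there is no precedent within this set to lean on. Compound 3 is expected to stay in the same region as compound 1, with a 1.7-fold higher number from compound 1 to compound 3 (0.23 log units; within the scatter) estimated to be small and, if anything, toward a higher number, but not clearly beyond the scatter. The estimate for compound 3 in this assay is 8000 nM, expected to fall between 1500 nM and 40000 nM.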

Compound 3, half-maximal inhibitory concentration: 1000 nM
Beside the measured number, compound 3's estimate is 8.0-fold (0.90 log units) above it; measured number outside the range, below it.
By their numbers in this assay, from the lowest: compound 3; then compounds 1 and 2 (each within the scatter of the next).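

In this assay, putting a group of 4 heavy atoms (1 carbon, 3 nitrogen; no ring) in place of a hydrogen atom, on a saturated chain carbon, four bonds along the chain from an amine nitrogen and a carbonyl carbon, gives a 4.7-fold lower number from compound 1 to compound 3 (0.67 log units; beyond the scatter), a modest gain in inhibition. This marks the chain carbon as a place where a single change moves the number, which compound 1 and compound 2 could not show, as they differ in more than one place and stand within the scatter of each other. Nothing available here explains the step. Going by these compounds, it remains open whether an amine or a carboxylic acid at this carbon would give a similar step, or whether this group needs this chain length. A longer chain carrying the same group, and the same change on the core of compound 2, are equally unresolved.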